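Shortening the acyl chain: propanoyl to acetyl

This account rests on a few compounds, and the source may have more. Where it says the series, first, only, none or still open, it means among the compounds named here.

Compound 1, `Cc1c(OCCCCOc2ccc(C(=O)O)cc2)ccc(C(=O)CC(C)C)c1O`, gives 51.9% in an assay on HEK293 cells for positive allosteric modulation of metabotropic glutamate receptor 3 (Rattus norvegicus), read by thallium flux, with a stated time of 2.5 min; a lower number here means a smaller maximal response, a higher number a larger maximal response.
Compound 2, `CCC(=O)c1ccc(OCCCCOc2ccc(F)c(C(=O)O)c2)c(C)c1O`, gives 18.4%.
Compound 3, `COC(=O)c1ccc(OCCCCOc2ccc(C(=O)CC3CCCC3)c(O)c2C)cc1`, gives 22%.

Compound 2 stands lowest of these three numbers. Compound 3 sits within the usual scatter of compound 2, so no order between them can be read; compound 1 stands beyond the scatter, higher.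

Compound 4, `CC(=O)c1ccc(OCCCCOc2ccc(F)c(C(=O)O)c2)c(C)c1O`, has not yet been measured. It differs from compound 2 in one place: hydrogen in place of methyl on a saturated chain carbon bound to a carbonyl carbon. Within the data shown here, no two measured compounds differ in this place alone, so no comparable step is known. In this assay the step is expected to be small, with no direction beyond the scatter. Compound 4 is estimated at 17%, between 5% and 35%, an expected step of a number 1.4 percentage points lower from compound 2 to compound 4 (within the scatter).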

Compound 4, largest response reached (reported as percent of maximum), in percent of the reference or control that the assay uses: 16.8%
Beside the measured number, compound 4's estimate is 0.2 percentage points above it; measured number inside the range.
By their numbers in this assay, from the lowest: compounds 4, 2 and 3 (each within the scatter of the next); then compound 1.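

Among these compounds, this is the first step measured at this place, the saturated chain carbon bound to a carbonyl carbon. In this assay, going from propanoyl to acetyl reads a number 1.6 percentage points lower from compound 2 to compound 4 (within the scatter) and so the two numbers cannot be told apart. For this pair, then, the methyl on that carbon makes no readable difference to the maximal response. Nothing measured here offers an explanation for this result. On these data alone, whether a much longer chain or an amine at this place would give a different number stays open, as does whether the same shortening would read alike on the core of compound 1.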